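The source may hold more compounds than are shown below. What is called first, only, known or untested is meant among the compounds shown, and "the series" means these compounds.

Working notes on the series.

Compound 1 `CCN(CC)CCn1c(N)c(-c2nc3ccccc3[nH]2)c2nc(C#N)c(C#N)nc21` is the starting point. In a functional assay on A549 cells (Homo sapiens) for antiproliferative activity, read by MTT assay, with a stated time of 48 h (a higher number here means a weaker inhibitor, a lower number a stronger inhibitor), compound 1 gives only a limit of the assay, > 50000 nM. Compound 2 `CN(C)CCCn1c(N)c(-c2nc3ccccc3[nH]2)c2nc(C#N)c(C#N)nc21` differs by (dimethylamino)methyl in place of diethylamino on a saturated chain carbon, two bonds along the chain from an aromatic nitrogen and gives 10400 nM in this assay; the step of an at least 4.8-fold lower number from compound 1 to compound 2 (0.68 log units; beyond the scatter) is the one readable move in the set. Compound 3 `CCN(CC)CCn1c(N)c(-c2nc3cc(Cl)ccc3[nH]2)c2nc(C#N)c(C#N)nc21` carries a second change, (chloro in place of hydrogen on an aromatic carbon), relative to compound 1. In this assay compound 3 gives only a limit, > 50000 nM. The step that the two limits leave unreadable from compound 1 to compound 3 cannot be read, because the limit of > 50000 nM in this assay, at which 2 of the 3 values shown sit, is where both ends of it sit.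

Compound 4 `CN(C)CCCn1c(N)c(-c2nc3cc(Cl)ccc3[nH]2)c2nc(C#N)c(C#N)nc21` is not yet measured. It stands to compound 3 as compound 2 stands to compound 1: the change (dimethylamino)methyl in place of diethylamino on a saturated chain carbon, two bonds along the chain from an aromatic nitrogen is the same change as (dimethylamino)methyl in place of diethylamino on a saturated chain carbon, two bonds along the chain from an aromatic nitrogen, and the place line is identical in both. The two cores differ by chloro in place of hydrogen on an aromatic carbon, the chloro that compound 3 and compound 4 share.

Since compound 3 is only a limit, the size of the step to compound 4 cannot be anchored to a number; the expectation rests on compound 1 giving > 50000 nM and compound 2 giving 10400 nM, so a step of about an at least 3.3-fold lower number from compound 3 to compound 4 (0.52 log units; beyond the scatter) is estimated for compound 4 if the chloro is neutral. On that basis compound 4 is expected to give about 15000 nM in this assay, estimated within 5000 nM to 50000 nM, with a real chance that only a limit is returned.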

Compound 4, half-maximal inhibitory concentration: > 50000 nM
Compound 4 was reported as a limit; the forecaster's own chance of this, stated with the estimate: 35%; at least 3.3-fold (0.52 log units) between middle value and limit.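

The change to 3-(dimethylamino)propyl on the core of compound 1 gives an at least 4.8-fold lower number from compound 1 to compound 2 (0.68 log units; beyond the scatter), but in this assay it cannot be followed on the chloro-bearing core, and the steps from compound 1 to compound 3 and from compound 3 to compound 4 cannot be read, because both ends of each are limits: the limit of > 50000 nM in this assay, at which 3 of the 4 values shown sit.

The one readable new move is chloro in place of hydrogen on an aromatic carbon with the 3-(dimethylamino)propyl chain in place, which gives an at least 4.8-fold higher number from compound 2 to compound 4 (0.68 log units; beyond the scatter), so the measurable activity of compound 2 does not survive on the chloro-bearing core. This does not show that the chain change has no effect there, as any difference between compound 3 and compound 4 lies out of reach of the assay, and one pair of cores sets no rule for the series.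

In the step from compound 1 to compound 2, chain length and the groups on the amine change together, and a 2-(dimethylamino)ethyl or a 3-(diethylamino)propyl chain would separate the two. Also open, as far as these compounds go, is whether the loss on going to compound 4 belongs to chloro in particular or would also follow from fluoro or methyl on that aromatic carbon.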